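The source may report more compounds than this note shows. Statements on the series, on what has been measured and on what is new or still open speak of the compounds shown alone.

Three close relatives of one shared core have been measured for agonist activity in an assay on cells for agonist activity at vitamin D3 receptor (Homo sapiens), with a stated time of 96 h; a higher number here means that more compound is needed for the effect, a lower number that less compound is needed. Compound 1 `CCN(CC)CCNC(=O)c1ccc(C(CC)(CC)c2ccc(OCCC(O)(CC)CC)c(C)c2)n1CC` gives 2.3 nM, compound 2 `CCOC(=O)C(CC(=O)OC)NC(=O)c1ccc(C(CC)(CC)c2ccc(OCCC(O)(CC)CC)c(C)c2)n1CC` gives 21 nM, and compound 3 `CCC(C)C(NC(=O)c1ccc(C(CC)(CC)c2ccc(OCCC(O)(CC)CC)c(C)c2)n1CC)C(=O)O` gives 860 nM, the highest of the three numbers. The two steps leading to compound 3 are both large: a 370-fold higher number from compound 1 to compound 3 (2.57 log units; beyond the scatter) and a 41-fold higher number from compound 2 to compound 3 (1.61 log units; beyond the scatter). Compound 4 `CCn1c(C(=O)NC(CO)CCO)ccc1C(CC)(CC)c1ccc(OCCC(O)(CC)CC)c(C)c1` differs from compound 3 in one place: 3-hydroxy-1-(hydroxymethyl)propyl in place of 1-carboxy-2-methylbutyl on an amide-type nitrogen. Both earlier steps show that replacing the 1-carboxy-2-methylbutyl group changed the number by a large amount in this assay, so a similarly large downward step is expected here. The estimated step is a 29-fold lower number from compound 3 to compound 4 (1.46 log units; beyond the scatter). Compound 4 is therefore expected to give about 30 nM, within a range of 8 nM to 150 nM.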

Compound 4, half-maximal effective concentration: 2490 nM
Beside the measured number, compound 4's estimate is 83-fold (1.92 log units) below it; the measured number lies above the stated range.
By their numbers in this assay, from the lowest: compound 1; then compound 2; then compound 3; then compound 4.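

Losing the 1-carboxy-2-methylbutyl group on the amide-type nitrogen does not by itself lower the number in this assay, since 3-hydroxy-1-(hydroxymethyl)propyl gives a 2.9-fold higher number from compound 3 to compound 4 (0.46 log units; beyond the scatter) and so moves it upward. The gaps to the other two groups are wider still, with a 120-fold higher number from compound 2 to compound 4 (2.07 log units; beyond the scatter) and a 1100-fold higher number from compound 1 to compound 4 (3.03 log units; beyond the scatter) at this same nitrogen, which puts compound 4 at the high end of the series. Nothing available explains this result. As far as these compounds go, whether a longer chain ending in a single hydroxyl, or a primary amine, would sit nearer compound 1 or compound 4 remains open.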